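A few compounds are considered here, and "the series" means these few. Any claim that something is new, unique, unknown or untested is made for them only; others in the source may bear on it.

Measured compounds:
compound 1 `Cc1nn(C)c(Oc2ccc(F)cc2)c1/C=N\CCCCCOc1cc2oc(=O)cc(C)c2cc1Cl` — in a functional assay on HepG2 cells (Homo sapiens) for antiproliferative activity, read by MTT assay, with a stated time of 72 h (a lower number here means a stronger inhibitor, a higher number a weaker inhibitor), compound 1 gives > 25000 nM
compound 2 `Cc1nn(C)c(Oc2ccc(Br)cc2)c1/C=N\CCCCCOc1cc2oc(=O)cc(C)c2cc1Cl` — in this assay compound 2 gives 13800 nM
compound 3 `Cc1nn(C)c(Oc2ccc(F)cc2)c1/C=N\CCCCCCOc1cc2oc(=O)cc(C)c2cc1Cl` — in this assay compound 3 gives 12500 nM

The value of compound 1 is a limit of the assay, (the limit of > 25000 nM in this assay, at which 1 of the 3 values shown sits), and not a number. Among the remaining two numbers compound 3 stands close to compound 2, the gap between them falling within the usual scatter of repeated measurements, so no order can be read between them.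

Compound 4 `Cc1nn(C)c(Oc2ccc(Br)cc2)c1/C=N\CCCCCCOc1cc2oc(=O)cc(C)c2cc1Cl` differs from compound 3 in one place: bromo in place of fluoro on an aromatic carbon. Among the compounds with values here, one measured step bears on the same change, an at least 1.8-fold lower number from compound 1 to compound 2 (0.25 log units; that floor lies within the scatter). As far as these compounds go, since one end of that step is only a limit, its true size is unknown; it may be small or larger. On this basis a modest move toward a lower number, or none beyond the scatter, is expected in this assay for compound 4.

The estimate for compound 4 is 8000 nM, with a range from 3000 nM to 20000 nM. The expected step, a 1.6-fold lower number from compound 3 to compound 4 (0.19 log units; within the scatter), is therefore a small one in the direction of the measured step.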

Compound 4, half-maximal inhibitory concentration: 4630 nM
For compound 4 the middle estimate is 1.7-fold (0.24 log units) above the measured one, within the range that was stated.
By their numbers in this assay, from the lowest: compound 4; then compounds 3 and 2 (each within the scatter of the next). At a limit, above all of these: compound 1.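

In this assay, the change from 4-fluorophenoxy to 4-bromophenoxy now gives a step with a number at both ends, and it is beyond the scatter: a 2.7-fold lower number from compound 3 to compound 4 (0.43 log units; beyond the scatter). Compound 1 gives > 25000 nM, which is a limit and not a number, so the earlier step could only offer a floor that lay within the scatter. The four compounds now show bromo giving the lower number on both cores, with none going against this, though the size of the two steps cannot be compared: the same change on two cores in this assay, an at least 1.8-fold lower number (0.25 log units; that floor lies within the scatter) from compound 1 to compound 2 and a 2.7-fold lower number (0.43 log units; beyond the scatter) from compound 3 to compound 4; the limit leaves it open whether they differ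

The compounds shown leave open whether another group at this place, such as chloro, iodo or an amine, would lower the number further. They also leave open whether a chain longer than that of compound 4 would do so, and why bromo gives the lower number here.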